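The compounds below may be only part of what the source reports. "The series", "measured", "known", "first", "only" and "open" are said of these compounds alone.

Working notes on the series. Compound 1 `CCOC(=O)c1sc(-c2cccc(NC(=O)c3ccccc3)c2)nc1Nc1ccc(N2CCN(C)CC2)cc1` gives 24800 nM in a functional assay on Ramos cells (Homo sapiens) for antiproliferative activity, read by CCK-8 assay, with a stated time of 72 h (a higher number here means a weaker inhibitor, a lower number a stronger inhibitor), and stands highest of the two numbers available. Going by the values given here, compound 3 `CCOC(=O)c1sc(-c2cccc(NC(=O)c3ccc(C#N)cc3)c2)nc1Nc1ccc(N2CCN(C)CC2)cc1` gives 4280 nM in this assay, the step of a 5.8-fold lower number from compound 1 to compound 3 (0.76 log units; beyond the scatter) being the one resolved change at the benzamido ring. For compound 2 `CCOC(=O)c1sc(-c2cccc(NC(=O)c3ccc(Cl)cc3)c2)nc1Nc1ccc(N2CCN(C)CC2)cc1` this assay gives "not determined" (no result reported), so it offers no number to compare. Compound 4 `CCOC(=O)c1sc(-c2cccc(NC(=O)c3ccc(F)c(Cl)c3)c2)nc1Nc1ccc(N2CCN(C)CC2)cc1` differs from compound 1 by 3-chloro-4-fluorophenyl in place of phenyl on a carbonyl carbon. Among the compounds with values here, only the step to compound 3 bears on this, and it was modest; a substituted benzamido ring has so far lowered the number, and a lowering of smaller or similar size is expected here. Compound 4 is therefore estimated at 9000 nM, with a range from 2500 nM to 30000 nM. That estimate means an expected step of a 2.8-fold lower number from compound 1 to compound 4 (0.44 log units; beyond the scatter).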

Compound 4, half-maximal inhibitory concentration: 29200 nM
Beside the measured number, compound 4's estimate is 3.2-fold (0.51 log units) below it, within the range that was stated.
By their numbers in this assay, from the lowest: compound 3; then compounds 1 and 4 (each within the scatter of the next).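

In this assay the change to 3-chloro-4-fluorophenyl on this carbonyl carbon gives a 1.2-fold higher number from compound 1 to compound 4 (0.07 log units; within the scatter) and so does not separate from phenyl: a substituent on this ring does not by itself lower the number. The change from 4-cyanophenyl gives a 6.8-fold higher number from compound 3 to compound 4 (0.83 log units; beyond the scatter) and leaves the lowering seen so far with compound 3 alone. No measurement shown here accounts for this difference. Still open, on these data alone, is whether an amine or a carboxylic acid in place of the nitrile would keep that lowering.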